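A Naphthyl Group Tried Where Three Analogues Showed Nothing

The compounds below may be only part of what the source reports. "The series", "measured", "known", "first", "only" and "open" are said of these compounds alone.

Measured so far in a functional assay on HL-60 cells (Homo sapiens), read by calcium flux; on this read-out higher numbers stand for an effect only at larger amounts of compound and lower numbers for an effect already at smaller amounts:
compound 1 `COc1cc(Cc2cc(C)nn(CC(=O)Nc3ccc(Br)cc3)c2=O)cc(OC)c1` gives only a limit of the assay, > 50000 nM
compound 2 `Cc1cc(Cc2ccc(C(F)(F)F)cc2)c(=O)n(CC(=O)Nc2ccc(Br)cc2)n1` gives only a limit of the assay, > 50000 nM
compound 3 `Cc1cc(Cc2ccsc2)c(=O)n(CC(=O)Nc2ccc(Br)cc2)n1` gives only a limit of the assay, > 50000 nM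

Compound 3 thus stands at the assay limit, not at a number. All three values share (the limit of > 50000 nM in this assay, at which 3 of the 3 values shown sit). The steps a step that the two limits leave unreadable from compound 1 to compound 2, a step that the two limits leave unreadable from compound 1 to compound 3 and a step that the two limits leave unreadable from compound 2 to compound 3 are therefore unreadable, since both ends of each are limits. Compound 4 `Cc1cc(Cc2cccc3ccccc23)c(=O)n(CC(=O)Nc2ccc(Br)cc2)n1` differs from compound 3 by naphthalen-1-yl in place of thiophen-3-yl on a saturated chain carbon bound to an aromatic carbon. With no readable step among the measured compounds, the expected step of a number no higher from compound 3 to compound 4 (the limit leaves the size open) in this assay cannot be derived and is only a guess. Compound 4 is therefore estimated at 50000 nM, within 10000 nM to 50000 nM, most likely again reported as a limit.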

Compound 4, half-maximal effective concentration: > 50000 nM
Compound 4: no number, only a limit; the forecaster's own chance of this, stated with the estimate: 80%; the middle value lies on the limit itself.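

In this assay no step from compound 1, compound 2 or compound 3 to compound 4 can be read, since all four values are limits: the limit of > 50000 nM in this assay, at which 4 of the 4 values shown sit.

The compounds shown leave open whether any group on this saturated chain carbon gives a measurable effect, and how the four compounds compare.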